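Bromo for fluoro on the sulfonyl aryl ring

A few compounds are considered here, and "the series" means these few. Any claim that something is new, unique, unknown or untested is made for them only; others in the source may bear on it.

Compound 1 `Cc1ccc(-c2nn(-c3ccccc3)cc2-c2nc3ccccc3n2S(=O)(=O)c2ccc(Br)cc2)cc1` gives 2340 nM in the assay below
Compound 2 `O=S(=O)(c1ccc(F)cc1)n1c(-c2cn(-c3ccccc3)nc2-c2ccc(F)cc2)nc2ccccc21` gives 2440 nM in the same assay

Both compounds were tested in a functional assay on HeLa cells (Homo sapiens) for antiproliferative activity, read by MTT assay, with a stated time of 24 h (on this read-out higher numbers stand for weaker inhibition and lower numbers for stronger inhibition), and their numbers lie within the usual scatter of each other. Compound 2 stands at 2440 nM on this read-out, so the two measurements cannot be ranked.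

Compound 3 `O=S(=O)(c1ccc(Br)cc1)n1c(-c2cn(-c3ccccc3)nc2-c2ccc(F)cc2)nc2ccccc21` has not yet been measured. It differs from compound 2 by a single exchange bromo in place of fluoro on an aromatic carbon in which bromo takes the place of fluoro on an aromatic carbon, para to a large group, so that 4-fluorophenyl becomes 4-bromophenyl. Going by the values given here, no measured pair of compounds differs in just one place, so the data offer no direct measure of this exchange. Among the compounds with values here, the only guide is the narrow spread of the two known values, with compound 1 at 2340 nM in this assay as the other reference point. The estimated change a 1.0-fold lower number from compound 2 to compound 3 (0.01 log units; within the scatter) is therefore expected to stay within the scatter, in neither direction. For compound 3 the expected value is 2400 nM with an estimated range from 1100 nM to 5000 nM in this assay.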

Compound 3, half-maximal inhibitory concentration: 2040 nM
For compound 3 the middle estimate is 1.2-fold (0.07 log units) above the measured one, and the stated range covers the measured number.
By their numbers in this assay, from the lowest: compounds 3, 1 and 2 (each within the scatter of the next).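

In this assay, going by these compounds alone, the first single exchange that can be read directly is bromo in place of fluoro on an aromatic carbon, para to a large group, which turns (4-fluorophenyl)sulfonyl into (4-bromophenyl)sulfonyl; it gives a 1.2-fold lower number from compound 2 to compound 3 (0.08 log units; within the scatter) and so shows that this position accepts either halogen without a change that can be told from the scatter. Compound 3 also links compound 1 to the series through a second exchange at another place, fluoro in place of methyl on an aromatic carbon, which gives a 1.1-fold lower number from compound 1 to compound 3 (0.06 log units; within the scatter), so neither of the two exchanges separates the three compounds on this read-out. No available evidence bears on why these exchanges leave the numbers so close together.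

The compounds shown carry only fluoro and bromo at the sulfonyl aryl position, so it remains open whether an amine, a carboxylic acid or a methoxy group at this place would keep the number in the same range. From the compounds shown here alone, whether the same flat picture holds outside this assay also remains open, as does the effect of removing the halogen altogether and leaving a plain phenyl group.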